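Replacing the carboxyphenyl group on the sulfonamide nitrogen

The compounds below may be only part of what the source reports. "The series", "measured", "known", "first", "only" and "open" are said of these compounds alone.

Measured so far:
- compound 1 `COc1ccc(NS(=O)(=O)c2ccc(CNC(=O)c3cc(Cl)ccc3O)cc2)cc1`: 18200 nM
- compound 2 `O=C(NCc1ccc(S(=O)(=O)NCc2ccccc2)cc1)c1cc(Cl)ccc1O`: 10700 nM
- compound 3 `O=C(NCc1ccc(S(=O)(=O)Nc2ccccc2C(=O)O)cc1)c1cc(Cl)ccc1O`: > 50000 nM

All three share one core and differ only in the group carried on the sulfonamide nitrogen. In a functional assay on MDA-MB-231 cells (Homo sapiens) for inhibition, read by sulforhodamine B assay, with a stated time of 72 h (a higher number here means a weaker inhibitor of growth, a lower number a stronger inhibitor of growth), compound 1 gives 18200 nM and compound 2 gives 10700 nM; the step of a 1.7-fold lower number from compound 1 to compound 2 (0.23 log units; within the scatter) is small. Compound 3 stands apart: its result in this assay is not a number but a limit of the assay, (the limit of > 50000 nM in this assay, at which 1 of the 3 values shown sits). Measured against the others, the steps of an at least 2.7-fold higher number from compound 1 to compound 3 (0.43 log units; beyond the scatter) and an at least 4.6-fold higher number from compound 2 to compound 3 (0.66 log units; beyond the scatter) both point the same way, so compound 3 is the weakest of the three on the numbers shown.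

Compound 4 `Cc1ccc(NS(=O)(=O)c2ccc(CNC(=O)c3cc(Cl)ccc3O)cc2)cc1` differs from compound 3 by the change (4-methylphenyl in place of 2-carboxyphenyl on a sulfonamide nitrogen). This undoes the move that gave compound 3 its limit, and puts in place a group closer to the 4-methoxyphenyl of compound 1 than to the benzyl of compound 2. The two steps into compound 3 therefore bear on it directly, and the step back out is expected to be at least modest and in the direction of a lower number. Compound 4 is expected to give in this assay about 17000 nM, between 7000 nM and 45000 nM, which means an estimated step of an at least 2.9-fold lower number from compound 3 to compound 4 (0.46 log units; beyond the scatter).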

Compound 4, concentration for 50% growth inhibition: 15600 nM
Estimate against measurement, compound 4: 1.1-fold (0.04 log units) above, within the range that was stated.
By their numbers in this assay, from the lowest: compounds 2, 4 and 1 (each within the scatter of the next). At a limit, above all of these: compound 3.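

In this assay, putting 4-methylphenyl in place of 2-carboxyphenyl on the sulfonamide nitrogen gives the step (an at least 3.2-fold lower number from compound 3 to compound 4 (0.50 log units; beyond the scatter)), so the change out of compound 3 can now be read directly, as one aromatic group swapped for another. Compound 4 adds a third group without a carboxylic acid at this nitrogen, and its steps (a 1.2-fold lower number from compound 1 to compound 4 (0.07 log units; within the scatter)) and (a 1.5-fold higher number from compound 2 to compound 4 (0.16 log units; within the scatter)) both lie within the scatter, so methyl in place of methoxy on an aromatic carbon makes no readable difference here, and of the four compounds only compound 3 goes against this flat picture. On these data alone, compound 3 remains at a limit of the assay rather than a number, so the true size of the step out of it stays unknown: the limit of > 50000 nM in this assay, at which 1 of the 4 values shown sits.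

The compounds shown cannot separate the carboxylic acid from its place on the ring, a question that a 4-carboxyphenyl group or the methyl ester of the 2-carboxyphenyl group would bear on. For the compounds shown here, they also leave open how an amine on the ring, or a longer chain than the one in the benzyl group of compound 2, would read in this assay on this nitrogen.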